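Chloro for methyl in a ligand series

The source may hold more compounds than are shown below. What is called first, only, known or untested is meant among the compounds shown, and "the series" means these compounds.

Measured so far:
Compound 1, `CS(=O)(=O)c1ccc(F)cc1NCC1=NCCN1`, gives 813 nM in an assay for binding affinity to Alpha-1A adrenergic receptor (Homo sapiens), read by radioligand binding; a lower number here means a stronger inhibitor, a higher number a weaker inhibitor.
Compound 2, `Cc1ccc(S(C)(=O)=O)c(NCC2=NCCN2)c1`, gives 776 nM in this assay.

Compound 2 has the lowest of the two numbers, yet the gap between it and compound 1 is within the usual scatter, so the two compounds cannot be told apart on this assay. Compound 3, `CS(=O)(=O)c1ccc(Cl)cc1NCC1=NCCN1`, has not yet been measured. It differs from compound 2 by one change: chloro in place of methyl on an aromatic carbon. Among the measured compounds shown here, only one measured step speaks to this kind of swap at this position. That step, a 1.0-fold lower number from compound 1 to compound 2 (0.02 log units; within the scatter), exchanged one small substituent for another and left the number essentially where it was. By the same reasoning a small exchange at the same aromatic carbon, this time chloro for methyl, is expected to stay within the scatter, with a 1.1-fold lower number from compound 2 to compound 3 (0.04 log units; within the scatter). Compound 3 is therefore estimated at 700 nM, with a range from 300 nM to 1600 nM.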

Compound 3, inhibition constant: 537 nM
Estimate against measurement, compound 3: 1.3-fold (0.12 log units) above; measured number inside the range.
By their numbers in this assay, from the lowest: compounds 3, 2 and 1 (each within the scatter of the next).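

The chloro result adds a third substituent at this aromatic carbon, para to a methylsulfonyl group, and gives a second swap against each earlier compound. In this assay, replacing methyl with chloro gives a 1.4-fold lower number from compound 2 to compound 3 (0.16 log units; within the scatter), and replacing fluoro with chloro gives a 1.5-fold lower number from compound 1 to compound 3 (0.18 log units; within the scatter), so compounds 1, 2 and 3 cannot be told apart, and fluoro, methyl and chloro are interchangeable here as far as these three compounds show. No evidence is available that bears on this result.

All three groups compared are single substituents without a ring or a charge, so the compounds shown leave open what an amine, a carboxylic acid or a longer chain at this carbon would do. They also leave open whether any change here can move the number beyond the scatter.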